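The compounds below may be only part of what the source reports. "The series", "measured", "known", "first", "only" and "open" are said of these compounds alone.

compound 2 `CC(C)=CCC[C@]1(C)/C=C/[C@@H](OC(=O)C=C(C)C)[C@](C)(O)/C=C/C(=O)/C(CCl)=C\C1`: 390 nM
compound 1 `CC(=O)O[C@]1(C)/C=C/C(=O)/C(CO)=C\C[C@](C)(CCC=C(C)C)/C=C/[C@H]1OC(=O)C=C(C)C`: 2010 nM
compound 3 `CC(C)=CCC[C@]1(C)/C=C/[C@@H](OC(=O)C=C(C)C)[C@](C)(O)/C=C/C(=O)/C(C[Si](c2ccccc2)(c2ccccc2)C(C)(C)C)=C\C1`: 20700 nM

In a functional assay on SW480 cells (Homo sapiens) for antiproliferative activity, read by MTT assay, with a stated time of 48 h (on this read-out lower numbers stand for stronger inhibition and higher numbers for weaker inhibition), compound 2 gives the lowest of the three numbers; compound 1 stands higher, beyond the scatter, and compound 3 stands higher still, also beyond the scatter. Compound 4 `CC(C)=CCC[C@]1(C)/C=C/[C@@H](OC(=O)C=C(C)C)[C@](C)(O)/C=C/C(=O)/C(C(=O)N(C(C)C)C(C)C)=C\C1` differs from compound 2 in one place: diisopropylcarbamoyl in place of chloromethyl on a double-bonded ring carbon. Within the data shown here, no pair of measured compounds differing in a single place is available to set the size of such an exchange. The larger groups seen so far go with weaker numbers, since compound 3 gives 20700 nM in this assay. An upward step beyond the scatter is therefore expected from compound 2 to compound 4, a 13-fold higher number from compound 2 to compound 4 (1.11 log units; beyond the scatter). Compound 4 is estimated at 5000 nM, with a range from 1500 nM to 20000 nM.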

Compound 4, half-maximal inhibitory concentration: 16000 nM
Compound 4: the middle estimate sits 3.2-fold (0.51 log units) below what was measured, and the stated range covers the measured number.
By their numbers in this assay, from the lowest: compound 2; then compound 1; then compounds 4 and 3 (each within the scatter of the next).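

In this assay, among these compounds, putting diisopropylcarbamoyl in place of chloromethyl on the double-bonded ring carbon gives a 41-fold higher number from compound 2 to compound 4 (1.61 log units; beyond the scatter), the only single-place step at hand for this position. It shows that this ring carbon does not tolerate every group alike, and that this exchange, which brings in far more heavy atoms, costs a large part of the inhibition. The data at hand offer no explanation for the step. Still open, on these data alone, is whether the amide itself or the bulk of its two isopropyl groups goes with the weaker number. A dimethylcarbamoyl or an aminomethyl group on the same carbon would help to separate the two.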